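A smaller saturated group replaces the bicyclic substituent

The compounds below may be only part of what the source reports. "The series", "measured", "known", "first", "only" and "open" are said of these compounds alone.

Compound 1 `CCCn1c(=O)c2nc([C@@H]3CC4C=CC3C4)[nH]c2n(CCC)c1=O` stands lowest of the two numbers in an assay on cell membranes for binding affinity to adenosine receptor A1 (Cavia porcellus), read by radioligand binding (on this read-out lower numbers stand for stronger inhibition and higher numbers for weaker inhibition), where compound 1 gives 4.3 nM. Compound 3 `CCCn1c(=O)c2nc(-c3cccn3C)[nH]c2n(CCC)c1=O` gives 140 nM in this assay. Compound 2 `CCCn1c(=O)c2nc(-c3nn[nH]n3)[nH]c2n(CCC)c1=O` reaches only the limit of this assay, at > 10000 nM. Compound 4 `CCCn1c(=O)c2nc(CC3CC3)[nH]c2n(CCC)c1=O` carries a group of 4 heavy atoms (4 carbon; one three-membered non-aromatic ring of carbon only) in place of a group of 7 heavy atoms (7 carbon; 2 five-membered non-aromatic rings of carbon only), on an aromatic carbon. The measured steps that bear on this change, an at least 2300-fold higher number from compound 1 to compound 2 (3.36 log units; beyond the scatter) and a 33-fold higher number from compound 1 to compound 3 (1.51 log units; beyond the scatter), both exchange the same group for a five-membered aromatic ring and both lose sharply. Since the group entering compound 4 is built of carbon only, as is the group it replaces, a smaller loss is expected than in those two steps. Compound 4 is therefore expected to give 50 nM, between 10 nM and 300 nM, which would mean a 12-fold higher number from compound 1 to compound 4 (1.07 log units; beyond the scatter).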

Compound 4, inhibition constant: 120 nM
For compound 4 the middle estimate is 2.4-fold (0.38 log units) below the measured one, and the stated range covers the measured number.
By their numbers in this assay, from the lowest: compound 1; then compounds 4 and 3 (each within the scatter of the next). At a limit, above all of these: compound 2.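

In this assay, a group of carbon only does not keep the number of compound 1, with a 28-fold higher number from compound 1 to compound 4 (1.45 log units; beyond the scatter), and cyclopropylmethyl and 1-methyl-1H-pyrrol-2-yl cannot be told apart at this place, with a 1.2-fold lower number from compound 3 to compound 4 (0.07 log units; within the scatter). 2H-Tetrazol-5-yl remains the outlier, with an at least 83-fold lower number from compound 2 to compound 4 (1.92 log units; beyond the scatter). The value of compound 2 is a limit of the assay, not a number: the limit of > 10000 nM in this assay, at which 1 of the 4 values shown sits.

The compounds shown leave open whether a cyclopentyl group or a longer chain such as butyl would come closer to compound 1. They also leave open whether a saturated ring carrying an amine would fall with cyclopropylmethyl or with 2H-tetrazol-5-yl.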